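The source may report more compounds than this note shows. Statements on the series, on what has been measured and on what is new or still open speak of the compounds shown alone.

In a functional assay on NCI-H460 cells (Homo sapiens) for cytotoxicity, read by sulforhodamine B assay, with a stated time of 3 days (a higher number here means a weaker inhibitor, a lower number a stronger inhibitor), compound 1 (`OCc1cn(Cc2ccc(Cl)cc2)c2ccccc12`) gives 16 nM and compound 2 (`Cc1ccc(Cn2cc(CO)c3ccccc32)cc1`) gives 31 nM on the same test. Compound 3 (`OCc1cn(Cc2ccc(Cl)cc2)c2ccc(F)cc12`) stands at 30 nM and lies within the scatter of both, so these numbers do not rank the three. Compound 4 (`Cc1ccc(Cn2cc(CO)c3cc(F)ccc32)cc1`) carries methyl in place of chloro on an aromatic carbon, para to a large group (methyl in place of chloro on an aromatic carbon). The same exchange was measured once without the fluoro, as a 1.9-fold higher number from compound 1 to compound 2 (0.29 log units; within the scatter) and so no clear shift. The fluoro itself, fluoro in place of hydrogen on an aromatic carbon, appears as a 1.9-fold higher number from compound 1 to compound 3 (0.27 log units; within the scatter) and also stays inside the scatter. Neither step gives firm ground, so in this assay no change beyond the scatter is expected, only a slight lean towards a higher number. The expected step is a 1.4-fold higher number from compound 3 to compound 4 (0.15 log units; within the scatter) and it remains an estimate. Compound 4 is estimated at 42 nM with an expected range from 18 nM to 95 nM in this test.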

Compound 4, half-maximal inhibitory concentration: 10 nM
Compound 4: middle estimate off by 4.2-fold (0.62 log units), on the high side; the measured number lies below the stated range.
By their numbers in this assay, from the lowest: compounds 4, 1, 3 and 2 (each within the scatter of the next, the first and the last beyond it).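

In this assay, methyl in place of chloro, para to a large group, gives a step beyond the scatter once the fluoro is present, a 3.0-fold lower number from compound 3 to compound 4 (0.48 log units; beyond the scatter), so the exchange does not carry over unchanged between the two cores: the same change on two cores in this assay, a 1.9-fold higher number (0.29 log units; within the scatter) from compound 1 to compound 2 and a 3.0-fold lower number (0.48 log units; beyond the scatter) from compound 3 to compound 4, 5.8-fold (0.76 log units) apart, beyond the scatter of two such steps

The fluoro reads the same way, with a 3.1-fold lower number from compound 2 to compound 4 (0.49 log units; beyond the scatter) where methyl is present, and its step does not carry over either: the same change on two cores in this assay, a 1.9-fold higher number (0.27 log units; within the scatter) from compound 1 to compound 3 and a 3.1-fold lower number (0.49 log units; beyond the scatter) from compound 2 to compound 4, 5.8-fold (0.76 log units) apart, beyond the scatter of two such steps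

Across these four compounds, then, the outcome of each change depends on the group present at the other place, and the two steps do not simply add.

As far as these compounds go, whether this holds for other groups stays open, since only chloro and methyl occupy the place para to a large group, and a methoxy group or a nitrile there could behave differently. These numbers cannot tell why the two changes depend on each other.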